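The source may hold more compounds than are shown below. What is called first, only, known or untested is meant among the compounds shown, and "the series" means these compounds.

Compound 1 `COc1ccc(Cn2cnc3c(N(C)c4ccc(OC)cc4)ncnc32)cc1` gives > 100000 nM in a functional assay on AGS cells (Homo sapiens) for antiproliferative activity, read by MTT assay, with a stated time of 48 h; on this read-out lower numbers stand for stronger inhibition of growth and higher numbers for weaker inhibition of growth. Compound 2 `COc1ccc(N(C)c2ncnc3c2ncn3Cc2ccc(OC)c(OC)c2)cc1` gives > 100000 nM. Compound 3 `COc1cc(Cn2cnc3c(Cl)ncnc32)cc(OC)c1` gives > 100000 nM.

Each of these values is a limit of this assay, not a number, since all three sit at the limit of > 100000 nM in this assay, at which 3 of the 3 values shown sit. Compound 2 differs from compound 1 by methoxy in place of hydrogen on an aromatic carbon, and the step that the two limits leave unreadable from compound 1 to compound 2 cannot be read from two limits. The difference between the core of compound 1 and the core of compound 3 is not broken down here.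

Compound 4 `COc1cc(Cn2cnc3c(Cl)ncnc32)cc(OC)c1OC` is not yet measured; it differs from compound 3 by methoxy in place of hydrogen on an aromatic carbon. This is the same kind of change as that from compound 1 to compound 2, though here the methoxy enters ortho to two methoxy groups and para to a large group, whereas earlier it entered ortho to a methoxy group and meta to a large group. Since compound 3 reaches only the limit > 100000 nM, the step that the limit leaves unreadable from compound 3 to compound 4 is expected to be unreadable as well. Compound 4 is estimated at 150000 nM, most likely again a limit.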

Compound 4, concentration for 50% growth inhibition: > 50000 nM
Compound 4: no number, only a limit; the forecaster's own chance of this, stated with the estimate: 85%; the middle value does not contradict the limit.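

Compound 3 and compound 4 both stand only at limits in this assay, and no step can be read between them. The compounds shown leave open whether methoxy in place of hydrogen on an aromatic carbon changes growth inhibition at all.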